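Swapping a Benzyloxy Group for a Nitrile on the Shared Core

The source may hold more compounds than are shown below. What is called first, only, known or untested is meant among the compounds shown, and "the series" means these compounds.

Of the compounds shown here, three with a shared core have been measured. In a functional assay on DLD-1 cells (Homo sapiens) for antiproliferative activity, read by CellTiter-Glo, with a stated time of 72 h (on this read-out lower numbers stand for stronger inhibition and higher numbers for weaker inhibition), compound 1 `CC1CCN(C2CCN(S(=O)(=O)c3cccc(Br)c3)CC2)CC1` gives 3.2 nM. In this assay compound 2 `CC1CCN(C2CCN(S(=O)(=O)c3cn(C)cn3)CC2)CC1` reaches only the limit of the assay, > 5000 nM (the limit of > 5000 nM in this assay, at which 1 of the 3 values shown sits). Going by the values given here, compound 3 `CC1CCN(C2CCN(S(=O)(=O)c3ccc(OCc4ccccc4)cc3)CC2)CC1` gives 385 nM in this assay, the higher of the two numbers known; compound 1 stands far lower. Compound 4 `CC1CCN(C2CCN(S(=O)(=O)c3ccc(C#N)cc3)CC2)CC1` differs from compound 3 in one place: cyano in place of benzyloxy on an aromatic carbon. Among the compounds with values here, the only measured step, an at least 1500-fold higher number from compound 1 to compound 2 (3.19 log units; beyond the scatter), exchanges the whole aromatic group rather than one substituent on a phenyl ring, so it shows only that this part of the molecule matters greatly. Compound 1 and compound 3 carry different groups on the phenyl ring, and their values lie far apart. A lower number is expected for compound 4, estimated at 40 nM, between 8 nM and 200 nM, which would mean a step of a 9.6-fold lower number from compound 3 to compound 4 (0.98 log units; beyond the scatter).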

Compound 4, half-maximal inhibitory concentration: 2800 nM
Estimate against measurement, compound 4: 70-fold (1.85 log units) below, and the stated range ends below it.
By their numbers in this assay, from the lowest: compound 1; then compound 3; then compound 4. At a limit, above all of these: compound 2.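

Replacing benzyloxy with the much smaller cyano on this aromatic carbon modestly weakens inhibition (a 7.3-fold higher number from compound 3 to compound 4 (0.86 log units; beyond the scatter)), so a small group here does not by itself give a low number. The 4-cyanophenyl group also falls far short of 3-bromophenyl (an 880-fold higher number from compound 1 to compound 4 (2.94 log units; beyond the scatter)). The remaining step (an at least 1.7-fold lower number from compound 2 to compound 4 (0.25 log units; that floor lies within the scatter)) rests on a limit and its floor lies within the scatter, so it sets no order. Compound 2 gives only a limit: the limit of > 5000 nM in this assay, at which 1 of the 4 values shown sits.

Still open, from the compounds shown here alone, is whether a methoxy group or an amine on this same carbon would give a lower number. Also open, going by these compounds, is whether compound 1 owes its low number to bromine itself or to where bromine sits on the ring.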